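Dichlorination of a benzyl purine-type core and cytotoxicity

A few compounds are considered here, and "the series" means these few. Any claim that something is new, unique, unknown or untested is made for them only; others in the source may bear on it.

Compound 1 `ClCc1ccc(Cn2cnc3c(Cl)ncnc32)cc1` gives 270 nM in a functional assay on SF-295 cells (Homo sapiens) for cytotoxicity, read by sulforhodamine B assay, with a stated time of 48 h; a lower number here means a stronger inhibitor of growth, a higher number a weaker inhibitor of growth. Compound 3 `ClCc1ccc(Cn2cnc3c(Cl)nc(Cl)nc32)cc1` differs from it by chloro in place of hydrogen on an aromatic carbon, and this change made a 27-fold higher number from compound 1 to compound 3 (1.43 log units; beyond the scatter). Compound 2 `ClCc1ccccc1Cn1cnc2ncnc(Cl)c21` has the same atoms as compound 1 joined differently; the difference between the two cores is not broken down here. In this assay compound 2 gives 7940 nM, while compound 3 gives 7240 nM.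

Compound 4 `ClCc1ccccc1Cn1cnc2nc(Cl)nc(Cl)c21` is not yet measured. It differs from compound 2 by chloro in place of hydrogen on an aromatic carbon, the same change as from compound 1 to compound 3. Compound 4 is expected to give 30000 nM in this assay, a step of a 3.8-fold higher number from compound 2 to compound 4 (0.58 log units; beyond the scatter) that is estimated smaller than the earlier one because compound 2 already stands at 7940 nM. The expected range for compound 4 runs from 8000 nM to 150000 nM.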

Compound 4, concentration for 50% growth inhibition: 20000 nM
For compound 4 the middle estimate is 1.5-fold (0.18 log units) above the measured one; the measured number falls inside the stated range.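

On the core of compound 2, chloro in place of hydrogen gave a 2.5-fold higher number from compound 2 to compound 4 (0.40 log units; beyond the scatter) in this assay. The change weakened growth inhibition on both cores, but its size did not carry over from one core to the other: the same change on two cores in this assay, a 27-fold higher number (1.43 log units; beyond the scatter) from compound 1 to compound 3 and a 2.5-fold higher number (0.40 log units; beyond the scatter) from compound 2 to compound 4, 11-fold (1.03 log units) apart, beyond the scatter of two such steps These two pairs show a shared direction, but they do not explain the difference in size and give no rule for any further core.

The compounds shown leave open whether an amine or a methoxy group on the aromatic carbon between two ring nitrogen atoms would follow the pattern of chloro. They also leave open how either core would respond if a hydroxymethyl group or a longer chain replaced the chloromethyl group.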